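Dihalophenyl versus naphthyl on the piperazine nitrogen

The source may report more compounds than this note shows. Statements on the series, on what has been measured and on what is new or still open speak of the compounds shown alone.

Measured compounds:
- compound 1, `Nc1scc(CN2CCN(c3cccc(Cl)c3Cl)CC2)c1C(=O)c1ccc(Cl)cc1`, -77%
- compound 2, `Nc1scc(CN2CCN(c3ccc(F)cc3Cl)CC2)c1C(=O)c1ccc(Cl)cc1`, -70%
- compound 3, `Nc1scc(CN2CCN(c3cccc4ccccc34)CC2)c1C(=O)c1ccc(Cl)cc1`, -21%

All three share one core and differ only in the aryl group on the amine nitrogen in the ring. In a functional assay on CHO cells with adenosine receptor A1 (Homo sapiens) as the target, read by cAMP accumulation and immunoassay, with a stated time of 6 min, tested at 10 uM (on this read-out lower numbers stand for a stronger effect and higher numbers for a weaker effect at the one concentration tested), compound 3 gives the highest number of the three: the nearest is compound 2, the furthest compound 1, both beyond the scatter. The two dihalophenyl compounds sit close together, a number 7 percentage points higher from compound 1 to compound 2 (within the scatter), while the move to the naphthyl group is large, a number 56 percentage points higher from compound 1 to compound 3 (beyond the scatter) and a number 49 percentage points higher from compound 2 to compound 3 (beyond the scatter).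

Compound 4, `Nc1scc(CN2CCN(c3cc(Cl)ccc3Cl)CC2)c1C(=O)c1ccc(Cl)cc1`, is not yet measured. The change from compound 3 is 2,5-dichlorophenyl in place of naphthalen-1-yl on an amine nitrogen in a ring. This returns to a dihalophenyl group of the kind carried by compound 1 and compound 2, so the steps from those two compounds to compound 3 bear on it in reverse. A large step downward is therefore expected, a number 49 percentage points lower from compound 3 to compound 4 (beyond the scatter), taking compound 4 back toward the range of compound 1 and compound 2. The estimate for compound 4 in this assay is -70%, with a range from -85% to -45%.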

Compound 4, a percentage reported as activity, at one concentration (the size of the read-out at that concentration, not a potency): -62%
Beside the measured number, compound 4's estimate is 8 percentage points below it; measured number inside the range.
By their numbers in this assay, from the lowest: compounds 1, 2 and 4 (each within the scatter of the next, the first and the last beyond it); then compound 3.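

In this assay the large gap to naphthalen-1-yl now holds for a third dihalophenyl group, with a number 41 percentage points lower from compound 3 to compound 4 (beyond the scatter) as the step, so on the amine nitrogen in a ring this gap is not tied to one halogen pattern. The dihalophenyl groups are not fully interchangeable, since a number 15 percentage points higher from compound 1 to compound 4 (beyond the scatter) is a modest step beyond the scatter, even though a number 8 percentage points higher from compound 2 to compound 4 (within the scatter) stays within it. Nothing available explains either the gap or the modest step.

These compounds cannot separate the second aromatic ring of naphthalen-1-yl from the absence of chlorine as the source of the gap. Also open, on these data alone, is whether phenyl carrying a single chlorine or a methoxy group would stay close to compound 4 at -62% or move toward compound 3 at -21% in this read-out.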